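Oxazole ketone series: aryl replaces trifluoromethyl carbonyl

The source may hold more compounds than are shown below. What is called first, only, known or untested is meant among the compounds shown, and "the series" means these compounds.

Working notes on the series. Three compounds share one core and differ only in the group on the five-membered ring. Compound 1 (`O=C(CCc1ccc(-c2ccccc2)cc1)c1ncc(-c2ccncc2)o1`) gives 2.3 nM in an assay for inhibition of Fatty-acid amide hydrolase 1 (Rattus norvegicus) (a lower number here means a stronger inhibitor, a higher number a weaker inhibitor), and serves as the reference. Compound 2 (`O=C(CCc1ccc(-c2ccccc2)cc1)c1ncc(-c2cccnc2)o1`) gives 1.1 nM in this assay, and the step of a 2.1-fold lower number from compound 1 to compound 2 (0.32 log units; beyond the scatter) is modest. Compound 3 (`O=C(CCc1ccc(-c2ccccc2)cc1)c1ncc(C(=O)C(F)(F)F)o1`) gives 8 nM in this assay and stands highest of the three numbers; its nearest neighbour is compound 1 through the step of a 3.5-fold higher number from compound 1 to compound 3 (0.54 log units; beyond the scatter) and its furthest is compound 2 through the step of a 7.3-fold higher number from compound 2 to compound 3 (0.86 log units; beyond the scatter), both beyond the scatter.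

Compound 4 (`O=C(O)c1ccc(-c2cnc(C(=O)CCc3ccc(-c4ccccc4)cc3)o2)nc1`) has not yet been measured in this assay. The change from compound 3 is 5-carboxypyridin-2-yl in place of (trifluoromethyl)carbonyl on an aromatic carbon and it sits on the same aromatic carbon that carried the earlier variations. Among the measured compounds shown here, the steps that bear on it are a 3.5-fold higher number from compound 1 to compound 3 (0.54 log units; beyond the scatter) and a 7.3-fold higher number from compound 2 to compound 3 (0.86 log units; beyond the scatter), in which a six-membered aromatic ring with one nitrogen gave way to the (trifluoromethyl)carbonyl and the number rose. Running that exchange the other way, toward the 5-carboxypyridin-2-yl, a lower number for compound 4 is expected, with the size a 3.2-fold lower number from compound 3 to compound 4 (0.51 log units; beyond the scatter) estimated from those two steps. For the measured compounds named here, the carboxylic acid has no precedent among the measured compounds, so the range is kept wide. Compound 4 is estimated at 2.5 nM in this assay, between 0.6 nM and 10 nM in range.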

Compound 4, inhibition constant: 14 nM
Beside the measured number, compound 4's estimate is 5.6-fold (0.75 log units) below it; measured number above the stated range.
By their numbers in this assay, from the lowest: compound 2; then compound 1; then compounds 3 and 4 (each within the scatter of the next).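

In this assay a six-membered aromatic ring with one nitrogen at this position, next to the ring oxygen, does not by itself give a low number: the step of a 6.1-fold higher number from compound 1 to compound 4 (0.78 log units; beyond the scatter) is modest and the step of a 13-fold higher number from compound 2 to compound 4 (1.10 log units; beyond the scatter) is large, whereas the earlier ring exchange between compound 1 and compound 2 was the smallest step in the series. The step of a 1.8-fold higher number from compound 3 to compound 4 (0.24 log units; within the scatter) leaves compound 4 and compound 3 within the scatter of each other, so the 5-carboxypyridin-2-yl and the (trifluoromethyl)carbonyl, two quite different groups, cannot be told apart here. The earlier link between an aryl group at this position and a lower number therefore holds for compound 1 and compound 2, and compound 4 goes against it.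

Nothing available speaks to what lies behind these steps. Since compound 4 differs from compound 1 and compound 2 in both the ring attachment and the carboxylic acid, the compounds shown leave open which of the two matters, and an unsubstituted pyridin-2-yl or a methyl ester in place of the carboxylic acid would bear directly on that question.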